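Diethylamino for dimethylamino on the butyl-linked amine

The compounds below may be only part of what the source reports. "The series", "measured", "known", "first", "only" and "open" are said of these compounds alone.

Measured so far in a functional assay on A549 cells (Homo sapiens) for antiproliferative activity, read by MTT assay, with a stated time of 48 h; a higher number here means a weaker inhibitor, a lower number a stronger inhibitor
- compound 1 (`CCN(CC)CCCCn1c(N)c(-c2nc3ccccc3o2)c2nc(C#N)c(C#N)nc21`) gives (9390 nM)
- compound 2 (`CN(C)CCn1c(N)c(-c2nc3cc(Cl)ccc3[nH]2)c2nc(C#N)c(C#N)nc21`) gives (> 50000 nM), a limit of the assay and not a number
- compound 3 (`CN(C)CCCCn1c(N)c(-c2nc3cc(Cl)ccc3[nH]2)c2nc(C#N)c(C#N)nc21`) gives (12100 nM)

Going by the values given here, compound 3 and compound 1 lie within the scatter of each other, and they hold the only two numbers in the set. Compound 4 (`CCN(CC)CCCCn1c(N)c(-c2nc3cc(Cl)ccc3[nH]2)c2nc(C#N)c(C#N)nc21`) is not yet measured. The change from compound 3 is (diethylamino in place of dimethylamino on a saturated chain carbon, four bonds along the chain from an aromatic nitrogen): diethylamino in place of dimethylamino on a saturated chain carbon, four bonds along the chain from an aromatic nitrogen.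

Among the compounds with values here, the only measured step, (an at least 4.1-fold lower number from compound 2 to compound 3 (0.61 log units; beyond the scatter)), lies beyond the scatter, but it places 2-(dimethylamino)ethyl where dimethylamino stood and keeps the amine end the same. It therefore bears on this change only loosely. Closer evidence comes from compound 1 (9390 nM), which already carries diethylamino at the same chain place but differs from compound 4 elsewhere on the core. Its value sits within the scatter of the value of compound 3 (12100 nM). No step beyond the scatter is therefore expected in this assay for this change, and the expected step, (a 1.2-fold lower number from compound 3 to compound 4 (0.06 log units; within the scatter)), is small. The estimate for compound 4 is (10500 nM), with an expected range from (4000 nM) to (27000 nM).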

Compound 4, half-maximal inhibitory concentration: 2270 nM
Compound 4: the middle estimate sits 4.6-fold (0.67 log units) above what was measured, outside the stated range (below it).
By their numbers in this assay, from the lowest: compound 4; then compounds 1 and 3 (each within the scatter of the next). At a limit, above all of these: compound 2.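

In this assay, the amine end on a saturated chain carbon, four bonds along the chain from an aromatic nitrogen, proves able to move the number beyond the scatter: a 5.3-fold lower number from compound 3 to compound 4 (0.73 log units; beyond the scatter). Going by these compounds alone, the earlier compounds held no pair differing only in this amine end, so this is the first direct reading of the change, and with diethylamino held fixed the group on the aromatic carbon also matters: a 4.1-fold lower number from compound 1 to compound 4 (0.62 log units; beyond the scatter). The step of an at least 22-fold lower number from compound 2 to compound 4 (1.34 log units; beyond the scatter) changes chain and amine end together and is only a bound, its starting value being a limit of the assay and not a number: the limit of > 50000 nM in this assay, at which 1 of the 4 values shown sits.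

The compounds shown leave open whether diethylamino in place of dimethylamino gives a similar step on the core of compound 1, and whether the trend continues to a larger amine such as dipropylamino or a ring amine such as piperidine. They also leave open what 2-(diethylamino)ethyl would give on the shorter chain, and they do not say why the number falls with this change.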